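A few compounds are considered here, and "the series" means these few. Any claim that something is new, unique, unknown or untested is made for them only; others in the source may bear on it.

Among the measured compounds shown here, in a functional assay on SK-OV-3 cells (Homo sapiens) for cytotoxicity, read by MTT assay, with a stated time of 24 h (on this read-out higher numbers stand for weaker inhibition and lower numbers for stronger inhibition), compound 2 `CCCCCCCC(=O)Nc1nnc(S[C@@H]2O[C@H](CO)[C@H](O)[C@H](O)[C@H]2O)s1` gives 56000 nM, and this is the only number available. Compound 1 `CCCCCCCCCCCCCC(=O)Nc1nnc(S[C@@H]2O[C@H](COC(C)=O)[C@H](OC(C)=O)[C@H](OC(C)=O)[C@H]2OC(C)=O)s1` is recorded as "not active" (no number reported). Compound 3 `CCCCCCCC/C=C\CCCCCCCCCCCC(=O)Nc1nnc(S[C@@H]2O[C@H](COC(C)=O)[C@H](OC(C)=O)[C@H](OC(C)=O)[C@H]2OC(C)=O)s1` is also recorded as "not active" (no number reported). Compound 2 therefore has no numerical neighbour, and no ranking on a scale can be drawn from these results.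

The next compound to be tested is compound 4 `CCCCCCCCCCCCCC(=O)Nc1nnc(S[C@@H]2O[C@H](CO)[C@H](O)[C@H](O)[C@H]2O)s1`. Its structure differs from that of compound 2 by hexyl in place of hydrogen on a saturated chain carbon, seven bonds along the chain from a carbonyl carbon. The change extends the saturated chain of compound 2 with hexyl and leaves the rest of the molecule untouched.

For the measured compounds named here, no measured pair shows a change of this kind, so the size of the step in this assay cannot be read from the data. A modest step toward stronger inhibition is expected, but this is a tentative expectation, and a result within the usual scatter would be no surprise. With compound 1 and compound 3 both reported without a number, a similar report for compound 4 also remains possible. The expected change is a 2.2-fold lower number from compound 2 to compound 4 (0.35 log units; beyond the scatter). For compound 4 the estimated value is 25000 nM, with an expected range from 7000 nM to 90000 nM.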

Compound 4, half-maximal inhibitory concentration: "not active" (no number reported)
Compound 4: no number reported; there is nothing to compare the estimate with.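

Among the compounds shown here, compound 4, like compound 1 and compound 3, is reported in this assay without a number, so no step from compound 2 to compound 4 can be read. The compounds shown leave open how extending the saturated chain of compound 2 with hexyl affects this read-out. No available evidence bears on this result.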